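This account rests on a few compounds, and the source may have more. Where it says the series, first, only, none or still open, it means among the compounds named here.

Measured compounds in a functional assay on cells (Cancer cell lines, Homo sapiens) for inhibition, read by MTT assay, with a stated time of 48 h; on this read-out higher numbers stand for weaker inhibition and lower numbers for stronger inhibition:
- compound 1, `Cc1ccc(/C=C/C(=O)NNC(=O)c2ccc3c(c2)OCCO3)cc1`: compound 1 gives 1050 nM
- compound 2, `O=C(/C=C/c1ccccc1Br)NNC(=O)c1ccc2c(c1)OCCO2`: compound 2 gives 2110 nM
- compound 3, `O=C(/C=C/c1ccccc1F)NNC(=O)c1ccc2c(c1)OCCO2`: compound 3 gives 4510 nM

Compound 3 stands at the highest number of the three, separated from compound 2 by a 2.1-fold higher number from compound 2 to compound 3 (0.33 log units; beyond the scatter) and from compound 1 by a 4.3-fold higher number from compound 1 to compound 3 (0.63 log units; beyond the scatter), both beyond the scatter; the gap between compound 1 and compound 2 is a 2.0-fold higher number from compound 1 to compound 2 (0.30 log units; within the scatter), within the scatter.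

Compound 4, `O=C(/C=C/c1ccccc1[N+](=O)[O-])NNC(=O)c1ccc2c(c1)OCCO2`, is not yet measured. It differs from compound 3 by nitro in place of fluoro on an aromatic carbon. Going by the values given here, the one measured step that touches this position is a 2.1-fold higher number from compound 2 to compound 3 (0.33 log units; beyond the scatter), where bromo in place of fluoro gives the lower number. Among the compounds with values here, no measured step introduces a nitro group anywhere, so the direction of the change is not settled by the data. Within the data shown here, since the only exchange at this position moved the number by a modest amount, a step of similar size is expected for compound 4 in this assay, more likely toward a lower number than compound 3 given a 2.1-fold higher number from compound 2 to compound 3 (0.33 log units; beyond the scatter), but with the opposite direction not excluded.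

The estimated step from compound 3 to compound 4 is a 1.5-fold lower number from compound 3 to compound 4 (0.18 log units; within the scatter). Compound 4 is therefore expected near 3000 nM, within a range of 1200 nM to 8000 nM.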

Compound 4, half-maximal inhibitory concentration: 890 nM
For compound 4 the middle estimate is 3.4-fold (0.53 log units) above the measured one; the measured number lies below the stated range.
By their numbers in this assay, from the lowest: compounds 4, 1 and 2 (each within the scatter of the next, the first and the last beyond it); then compound 3.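

In this assay, the aromatic carbon ortho to a large group tolerates a wider spread than the exchange of the two halogens alone had shown, with nitro in place of fluoro giving a 5.1-fold lower number from compound 3 to compound 4 (0.70 log units; beyond the scatter). Nitro also separates from bromo, with a 2.4-fold lower number from compound 2 to compound 4 (0.37 log units; beyond the scatter), so the three groups at this place give three distinct levels, and nitro, the only one of them that is not a halogen, gives the lowest number of the three. Against the 4-methylphenyl compound, the 2-nitrophenyl change gives a 1.2-fold lower number from compound 1 to compound 4 (0.07 log units; within the scatter), so a group at this place can match that compound, whereas fluoro, in compound 3, does not.

Nothing available explains why nitro differs from the two halogens, and the order of the three groups therefore remains a description only. Also open, from the compounds shown here alone, is whether this order extends to other groups on the same aromatic carbon, such as an amine or a carboxylic acid, and whether nitro gives a similar change when placed elsewhere on the ring or on a compound with a different core.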